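From Cyanophenyl to Bromophenyl on the Aromatic Nitrogen

A few compounds are considered here, and "the series" means these few. Any claim that something is new, unique, unknown or untested is made for them only; others in the source may bear on it.

Compound 1, `N#Cc1ccccc1-n1cc(COc2cccc(NC(=O)Nc3ccc(Cl)c(C(F)(F)F)c3)c2)nn1`, gives 1970 nM in a functional assay on HepG2 cells (Homo sapiens) for inhibition, read by MTT assay, with a stated time of 72 h; a lower number here means a stronger inhibitor, a higher number a weaker inhibitor.
Compound 2, `N#Cc1cccc(-n2cc(COc3cccc(NC(=O)Nc4ccc(Cl)c(C(F)(F)F)c4)c3)nn2)c1`, gives 2760 nM in this assay.
Compound 3, `N#Cc1ccc(-n2cc(COc3cccc(NC(=O)Nc4ccc(Cl)c(C(F)(F)F)c4)c3)nn2)cc1`, gives 2980 nM in this assay.

These three compounds share one core and differ only in where the nitrile sits on the phenyl group attached to the aromatic nitrogen. On the numbers shown, compound 3 has the highest value of the three, yet every step separating it from the others is within the scatter: a 1.1-fold higher number from compound 2 to compound 3 (0.03 log units; within the scatter) and a 1.5-fold higher number from compound 1 to compound 3 (0.18 log units; within the scatter), and likewise a 1.4-fold higher number from compound 1 to compound 2 (0.15 log units; within the scatter). Moving the nitrile around that ring produced no shift that can be trusted.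

Compound 4, `O=C(Nc1cccc(OCc2cn(-c3ccccc3Br)nn2)c1)Nc1ccc(Cl)c(C(F)(F)F)c1`, changes this part of the molecule in a different way: 2-bromophenyl in place of 4-cyanophenyl on an aromatic nitrogen. Among the measured compounds shown here, no measured step exchanges the nitrile for a bromine, so nothing directly predicts the outcome. Compound 4 is nevertheless expected to land close to compound 3, because a 1.1-fold higher number from compound 2 to compound 3 (0.03 log units; within the scatter) and a 1.5-fold higher number from compound 1 to compound 3 (0.18 log units; within the scatter) show that variation at this position has so far stayed within the scatter, and a 1.2-fold lower number from compound 3 to compound 4 (0.08 log units; within the scatter) is estimated to do the same. The estimate for compound 4 in this assay is 2500 nM, with an expected range from 900 nM to 7000 nM.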

Compound 4, half-maximal inhibitory concentration: 2810 nM
The estimate for compound 4 lay 1.1-fold (0.05 log units) below the measured number, within the range that was stated.
By their numbers in this assay, from the lowest: compounds 1, 2, 4 and 3 (each within the scatter of the next).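

Exchanging the cyanophenyl group for 2-bromophenyl produces no reliable shift: there is a 1.1-fold lower number from compound 3 to compound 4 (0.03 log units; within the scatter), a 1.0-fold higher number from compound 2 to compound 4 (0.01 log units; within the scatter) and a 1.4-fold higher number from compound 1 to compound 4 (0.15 log units; within the scatter). The earlier compounds shown here showed only that the nitrile could occupy different places on the ring, whereas compound 4 has no nitrile, and its bromine-bearing group has no triple bond and no hydrogen-bond acceptor, yet all these steps stay within the scatter in this assay. No measurement shown explains why this position gives such similar numbers.

On these data alone, all four compounds carry a substituted phenyl group on the aromatic nitrogen, so it remains open whether the numbers would stay this close with a phenyl group bearing an amine or a carboxylic acid, or with a longer carbon chain in place of the ring. As far as these compounds go, every value comes from this assay, so how these compounds compare in any other test also remains open.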